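Compound 4: one open step from compound 3

A few compounds are considered here, and "the series" means these few. Any claim that something is new, unique, unknown or untested is made for them only; others in the source may bear on it.

Measured in an ADME assay on HEK293 cells (Homo sapiens) for cytotoxicity, read by MTT assay, with a stated time of 24 h; a higher number here means a weaker inhibitor, a lower number a stronger inhibitor:
compound 1 `CN(C)CCCNc1nc2cc([N+](=O)[O-])ccc2nc1NCc1ccc(F)cc1`: 4.28 ug/mL
compound 2 `CN(C)CCCNc1nc2cc([N+](=O)[O-])ccc2nc1NCc1ccccc1C(F)(F)F`: 24.7 ug/mL
compound 3 `CN(C)CCCNc1nc2cc([N+](=O)[O-])ccc2nc1NCc1cccc(Br)c1`: 3.66 ug/mL

Compound 3 stands level with compound 1, with a 1.2-fold lower number from compound 1 to compound 3 (0.07 log units; within the scatter). The wider gap is a 6.7-fold lower number from compound 2 to compound 3 (0.83 log units; beyond the scatter).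

Compound 4 `CN(C)CCCNc1nc2cc([N+](=O)[O-])ccc2nc1NCc1ccc(Cl)c(C(F)(F)F)c1` has 4-chloro-3-(trifluoromethyl)phenyl in place of 3-bromophenyl on a saturated chain carbon bound to a nitrogen on an aromatic ring.

Among the compounds with values here, two measured steps bear on this. One exchange of groups at that place gave a 1.2-fold lower number from compound 1 to compound 3 (0.07 log units; within the scatter), while the exchange that brought in a trifluoromethyl group gave a 5.8-fold higher number from compound 1 to compound 2 (0.76 log units; beyond the scatter). A small rise in this assay is therefore expected, possibly none beyond the scatter. The expected step is a 1.6-fold higher number from compound 3 to compound 4 (0.21 log units; within the scatter). For compound 4 the estimated value is 6 ug/mL, with an expected range of 2.5 ug/mL to 20 ug/mL.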

Compound 4, half-maximal inhibitory concentration: 3.26 ug/mL
The estimate for compound 4 lay 1.8-fold (0.26 log units) above the measured number; the measured number falls inside the stated range.
By their numbers in this assay, from the lowest: compounds 4, 3 and 1 (each within the scatter of the next); then compound 2.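

In this assay, the larger 4-chloro-3-(trifluoromethyl)phenyl stays level with the smaller groups, with a 1.1-fold lower number from compound 3 to compound 4 (0.05 log units; within the scatter) and a 1.3-fold lower number from compound 1 to compound 4 (0.12 log units; within the scatter), yet stands well apart from 2-(trifluoromethyl)phenyl, with a 7.6-fold lower number from compound 2 to compound 4 (0.88 log units; beyond the scatter). A trifluoromethyl group at this place therefore does not by itself raise the number, and among these compounds, only compound 2 stands apart. No measurement shown accounts for this difference.

On these data alone, it remains open whether a phenyl ring carrying a nitrile, an amine or a carboxylic acid would stay level with compound 3 and compound 4.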